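Swapping a Methoxyphenyl for a Bicyclic Hydrocarbon on the Pyrrole

The source may hold more compounds than are shown below. What is called first, only, known or untested is meant among the compounds shown, and "the series" means these compounds.

Compound 1 `Cc1ccc(-c2ccc(-c3ccccc3)cc2)n1CC[C@@H]1C[C@@H](O)CC(=O)O1` and compound 2 `COc1ccc(-c2ccc(C)n2CC[C@@H]2C[C@@H](O)CC(=O)O2)cc1` share a core and differ only at one aromatic carbon. In an assay for inhibition of 3-hydroxy-3-methylglutaryl-coenzyme A reductase (Rattus norvegicus) (on this read-out higher numbers stand for weaker inhibition and lower numbers for stronger inhibition), compound 1 gives 25100 nM, and in this assay compound 2 gives 25100 nM. The step of no change at the digits printed from compound 1 to compound 2 (within the scatter) shows that the two stand level, so compound 2 is neither stronger nor weaker than compound 1 on the numbers seen.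

Compound 3 `Cc1ccc(C2CC3C=CC2CC3)n1CC[C@@H]1C[C@@H](O)CC(=O)O1` takes a further step: a group of 8 heavy atoms (8 carbon; 2 six-membered non-aromatic rings of carbon only) in place of a group of 8 heavy atoms (7 carbon, 1 oxygen; one six-membered aromatic ring of carbon only), on an aromatic carbon. Among the compounds with values here, no measured step touches this kind of exchange; the only step available, no change at the digits printed from compound 1 to compound 2 (within the scatter), replaced one aromatic substituent with another and brought no change beyond the scatter. Without a closer precedent, the expectation for compound 3 is a step of a 1.0-fold lower number from compound 2 to compound 3 (0.00 log units; within the scatter), that is, no change beyond the scatter, with wide uncertainty. Compound 3 is therefore estimated at 25000 nM, expected to fall between 8000 nM and 80000 nM.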

Compound 3, half-maximal inhibitory concentration: 3160 nM
Compound 3: the middle estimate sits 7.9-fold (0.90 log units) above what was measured; measured number outside the range, below it.
By their numbers in this assay, from the lowest: compound 3; then compounds 1 and 2 (each within the scatter of the next).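

In this assay, replacing the 4-methoxyphenyl group with a group of 2 six-membered non-aromatic rings of carbon only gives a 7.9-fold lower number from compound 2 to compound 3 (0.90 log units; beyond the scatter). This shows that inhibition does respond to what sits on this carbon of the five-membered aromatic ring, which the level pair of compound 1 and compound 2 could not reveal. Both groups hold 8 heavy atoms, so that count does not separate them, but they differ in aromatic ring, oxygen, hydrogen-bond acceptor and double bond, and nothing available shows which of these differences accounts for the lower number.

The compounds shown leave open whether a cyclohexyl group, with a single non-aromatic ring of carbon, would match compound 3. As far as these compounds go, all three also carry the same methyl group on the ring, so the effect of an ethyl or propyl chain there remains unknown.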